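The source may report more compounds than this note shows. Statements on the series, on what has been measured and on what is new or still open speak of the compounds shown alone.

Measured in a functional assay on Daudi cells (Homo sapiens) for antiproliferative activity; a higher number here means a weaker inhibitor, a lower number a stronger inhibitor:
- compound 1 `Nc1ncnc2c1c(-c1ccc(Oc3ccccc3)cc1)cn2C[C@H]1CCCN1C[C@@H](O)CO` gives 14400 nM
- compound 2 `Nc1ncnc2c1c(-c1cnc3[nH]ccc3c1)cn2[C@H]1CCN(C[C@@H]2CO2)C1` gives 2990 nM
- compound 3 `Nc1ncnc2c1c(-c1cnc3[nH]ccc3c1)cn2C[C@H]1CCCN1C[C@@H]1CO1` gives "not determined" (no result reported)

Compound 1 holds the higher of the two numbers, and compound 2 lies below it, beyond the scatter. Compound 4 `Nc1ncnc2c1c(-c1ccc(Oc3ccccc3)cc1)cn2C[C@H]1CCCN1C[C@@H]1CO1` is not yet measured. It differs from compound 1 by oxiran-2-yl in place of 1,2-dihydroxyethyl on a saturated chain carbon bound to an amine nitrogen in a ring. Among the measured compounds shown here, no measured pair isolates this change, so its size remains uncertain. Compound 2 also carries oxiran-2-yl and gives 2990 nM on a different structure, so a lower number beyond the scatter is expected in this assay for this change. The expected size is a 5.8-fold lower number from compound 1 to compound 4 (0.76 log units; beyond the scatter) on this estimate. Compound 4 is estimated at 2500 nM (range 500 nM to 10000 nM).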

Compound 4, half-maximal inhibitory concentration: 7040 nM
The estimate for compound 4 lay 2.8-fold (0.45 log units) below the measured number; measured number inside the range.
By their numbers in this assay, from the lowest: compound 2; then compound 4; then compound 1.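

In this assay, among the compounds shown here, the change to oxiran-2-yl from 1,2-dihydroxyethyl, on a saturated chain carbon bound to an amine nitrogen in a ring, gives a 2.0-fold lower number from compound 1 to compound 4 (0.31 log units; beyond the scatter) and so provides the first reading of this change on a single structure. The step is modest, so at this position on this core the oxiran-2-yl group brings only a limited shift. Nothing available explains the shift.

On these data alone, whether the step carries over to the core of compound 2 remains open. Also open, as far as these compounds go, is how an amine, a carboxylic acid or a longer chain would compare at this position.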